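Replacing the 2-methyl-1,3-thiazol-4-yl group of compound 1

The source may hold more compounds than are shown below. What is called first, only, known or untested is meant among the compounds shown, and "the series" means these compounds.

For the measured compounds named here, in a functional assay on HeLa cells (Homo sapiens) for antiproliferative activity, read by MTT assay, with a stated time of 72 h (on this read-out higher numbers stand for weaker inhibition and lower numbers for stronger inhibition), compound 1 `Cc1nc(C(=O)Nc2ccc(Cl)c(-c3nnc4c(Cl)cccn34)c2)cs1` gives 79800 nM as the only actual number so far. Compound 2 `O=C(Nc1ccc(Cl)c(-c2nnc3c(Cl)cccn23)c1)c1ccc(Cl)cc1Cl` reads > 100000 nM in this assay and that reading is a limit of the assay, not a number. Compound 3 `O=C(Nc1ccc(Cl)c(-c2nnc3c(Cl)cccn23)c1)c1c(F)cccc1Cl` has not yet been measured. Relative to compound 1, it has 2-chloro-6-fluorophenyl in place of 2-methyl-1,3-thiazol-4-yl on a carbonyl carbon, with the shared core unchanged and 2-chloro-6-fluorophenyl in place of 2-methyl-1,3-thiazol-4-yl on a carbonyl carbon as the counted difference between the two structures. Going by the values given here, the only measured step bearing on this change, an at least 1.2-fold higher number from compound 1 to compound 2 (0.09 log units; that floor lies within the scatter), leads to the expectation of a small step toward weaker inhibition in this assay, possibly none beyond the scatter. For compound 2 the reference point is the limit of > 100000 nM in this assay, at which 1 of the 2 values shown sits, and nothing finer is known. The expected size of the change is a 1.3-fold higher number from compound 1 to compound 3 (0.10 log units; within the scatter) on this estimate. Compound 3 is estimated at 100000 nM with 45000 nM to 220000 nM as the expected range.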

Compound 3, half-maximal inhibitory concentration: > 100000 nM
Compound 3: no number, only a limit (the forecaster's own chance of this, stated with the estimate: 60%); the middle value sits exactly at the limit.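

In this assay compound 3 gives > 100000 nM, which is a limit of the assay and not a number. The change to 2-chloro-6-fluorophenyl on this carbonyl carbon gives an at least 1.2-fold higher number from compound 1 to compound 3 (0.09 log units; that floor lies within the scatter), so a real loss of activity relative to the 2-methyl-1,3-thiazol-4-yl group is not established, and the step between compound 2 and compound 3 cannot be read. A second halogen-bearing phenyl group now sits with 2,4-dichlorophenyl at the top of the measurable range, and no phenyl group shown at this place yields a number: the limit of > 100000 nM in this assay, at which 2 of the 3 values shown sit.

Going by these compounds, it remains open how far compound 2 and compound 3 lie past the limit. On these data alone, it also remains open whether any group on this carbonyl carbon moves the reading of compound 1, 79800 nM, beyond the scatter. As far as these compounds go, the readings with a morpholine on this carbonyl carbon, or with a phenyl group carrying a carboxylic acid, are also open.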